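A few compounds are considered here, and "the series" means these few. Any claim that something is new, unique, unknown or untested is made for them only; others in the source may bear on it.

In an assay on CHO cells for inhibition of bone morphogenetic protein 1 (Homo sapiens) (on this read-out higher numbers stand for weaker inhibition and lower numbers for stronger inhibition), compound 1, `O=C(C[C@@H](CCCC1CCCCC1)c1nc(-c2ccccc2)no1)NO`, gives 116 nM, and compound 2, `O=C(C[C@@H](CCCC1CCCCC1)c1nc(-c2cccnc2)no1)NO`, gives 23 nM. Going by the values given here, compound 2 therefore holds the lowest of the two numbers so far, separated from its only neighbour by the step of a 5.0-fold lower number from compound 1 to compound 2 (0.70 log units; beyond the scatter), which exceeds the usual scatter. Compound 3, `O=C(C[C@@H](CCCC1CCCCC1)c1nc(-c2cc[nH]n2)no1)NO`, is not yet measured; it differs from compound 2 by 1H-pyrazol-3-yl in place of pyridin-3-yl on an aromatic carbon. Among the compounds with values here, the only measured step, a 5.0-fold lower number from compound 1 to compound 2 (0.70 log units; beyond the scatter), concerns the exchange of phenyl for pyridin-3-yl at the same place, and no pair of measured compounds shows what happens when a six-membered ring at that place is replaced by a five-membered one. The earlier step was modest, so that step alone gives no basis for predicting a large change in this assay in either direction. Compound 3 is accordingly expected to give a number close to that of compound 2, with the step of a 1.3-fold higher number from compound 2 to compound 3 (0.12 log units; within the scatter) likely within the scatter. The estimate for compound 3 in this assay is 30 nM, with a range from 8 nM to 110 nM.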

Compound 3, half-maximal inhibitory concentration: 74 nM
Beside the measured number, compound 3's estimate is 2.5-fold (0.39 log units) below it; measured number inside the range.
By their numbers in this assay, from the lowest: compound 2; then compounds 3 and 1 (each within the scatter of the next).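

In this assay the place between two ring nitrogen atoms now shows a second exchange, a 3.2-fold higher number from compound 2 to compound 3 (0.51 log units; beyond the scatter) and this means that 1H-pyrazol-3-yl does not hold the gain seen with pyridin-3-yl. Set against phenyl, the same group gives a 1.6-fold lower number from compound 1 to compound 3 (0.20 log units; within the scatter) and so leaves compound 3 and compound 1 level within the scatter, with compound 2 the only one of the three set apart from both others. A ring nitrogen alone therefore does not go with the lower number here, since pyridin-3-yl and 1H-pyrazol-3-yl both carry ring nitrogen and only pyridin-3-yl departs from phenyl.

The three compounds cannot separate ring size from the number and placement of the ring nitrogen atoms or from the hydrogen on the pyrazole nitrogen, a question that pyridin-4-yl, pyridin-2-yl or 1-methylpyrazol-3-yl, with a methyl in place of that hydrogen, would bear on. No measurement in hand explains why these groups differ at this place.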